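The compounds below may be only part of what the source reports. "The series", "measured", "known", "first", "only" and "open" are said of these compounds alone.

Two compounds have been measured in a functional assay on A-375 cells (Homo sapiens) for antiproliferative activity; on this read-out lower numbers stand for stronger inhibition and higher numbers for weaker inhibition:

Compound 1 `c1ccc2c(-c3cnc4[nH]nc(-c5nc6ccccc6[nH]5)c4c3)cncc2c1`: 870 nM
Compound 2 `CC(C)OCc1cccc2[nH]c(-c3n[nH]c4ncc(-c5cncc6ccccc56)cc34)nc12`: 910 nM

Going by the values given here, compound 2 stands within the scatter of compound 1, the only other number available, so the two cannot be ordered; the step of a 1.0-fold higher number from compound 1 to compound 2 (0.02 log units; within the scatter) shows that placing isopropoxymethyl on that aromatic carbon left the read-out essentially unchanged. Compound 3 `CCN(CC)C(=O)c1cccc2[nH]c(-c3n[nH]c4ncc(-c5cncc6ccccc56)cc34)nc12` is the next compound in the series, and it differs from compound 2 in one place: diethylcarbamoyl in place of isopropoxymethyl on an aromatic carbon. Among the compounds with values here, the one measured step that bears on this change is the step from compound 1 to compound 2, which touched the same aromatic carbon and stayed within the scatter. Within the data shown here, that is the only guidance; no step involving a diethylcarbamoyl group, or any carbonyl-bearing substituent, has been measured. On this basis the change from compound 2 to compound 3 is expected to give a step of a 1.0-fold lower number from compound 2 to compound 3 (0.00 log units; within the scatter), that is, nothing beyond the usual scatter. Compound 3 is therefore estimated at 900 nM, with a range from 400 nM to 2000 nM.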

Compound 3, half-maximal inhibitory concentration: 71 nM
Compound 3: the middle estimate sits 13-fold (1.10 log units) above what was measured; measured number outside the range, below it.
By their numbers in this assay, from the lowest: compound 3; then compounds 1 and 2 (each within the scatter of the next).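

In this assay the aromatic carbon that took isopropoxymethyl with no readable change proves to respond strongly to what is placed on it: diethylcarbamoyl in place of isopropoxymethyl gives a 13-fold lower number from compound 2 to compound 3 (1.11 log units; beyond the scatter) on the read-out. Set against hydrogen, the same group gives a 12-fold lower number from compound 1 to compound 3 (1.09 log units; beyond the scatter) so the drop appears against both earlier compounds, and the flat step between those two says something about isopropoxymethyl rather than about this position as a whole. The two groups have the same counts of hydrogen-bond donors and acceptors and neither carries a net charge, so those counts do not separate them, while diethylcarbamoyl brings a carbonyl and a nitrogen that isopropoxymethyl lacks.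

Nothing at hand accounts for the size of this difference. The compounds shown also leave open whether the carbonyl, the amide nitrogen or the two ethyl chains carry the effect, a question that a dimethylamide, a primary amide, a carboxylic acid or an aminomethyl group on this same carbon would help to settle.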